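The compounds below may be only part of what the source reports. "The series", "measured", "known", "first", "only" and "open" are said of these compounds alone.

Of the compounds shown here, three sharing one core have been measured in a functional assay on HEK293 cells for positive allosteric modulation of metabotropic glutamate receptor 5 (Homo sapiens), read by calcium flux; a lower number here means a smaller maximal response, a higher number a larger maximal response. Compound 1 `O=C1c2cc(COc3ccccc3)nn2CCN1c1ccccc1F` gives 86%. Compound 2 `O=C1c2cc(COc3ccccc3)nn2CCN1c1ccc(F)cc1` gives 79%. Compound 3 `O=C1c2cc(COc3ccccc3)nn2CCN1c1ccccn1` gives 69%. Where compound 3 stands is set by two steps: a number 17 percentage points lower from compound 1 to compound 3 (beyond the scatter), which lies beyond the scatter, and a number 10 percentage points lower from compound 2 to compound 3 (within the scatter), which lies within it, so compound 3 is separated with confidence only from compound 1.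

The unmeasured compound 4 `O=C1c2cc(COc3ccccc3)nn2CCN1c1cccnc1` differs from compound 3 by pyridin-3-yl in place of pyridin-2-yl on an amide-type nitrogen in a ring. Within the data shown here, the change stays at the amide-type nitrogen in the ring, so the steps that bear on it are a number 17 percentage points lower from compound 1 to compound 3 (beyond the scatter) and a number 10 percentage points lower from compound 2 to compound 3 (within the scatter), together with a number 7 percentage points lower from compound 1 to compound 2 (within the scatter): all three exchange one six-membered aromatic group for another at that nitrogen, and none exceeds a modest size. Among the measured compounds shown here, no measured step contrasts pyridin-2-yl with pyridin-3-yl. For compound 4 a step of about a number 3 percentage points higher from compound 3 to compound 4 (within the scatter) is expected, a change that would not rise beyond the scatter. Compound 4 is therefore estimated at 72%, in the range 57% to 87%.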

Compound 4, largest response reached (Emax), in percent of the reference or control that the assay uses: 64%
Beside the measured number, compound 4's estimate is 8 percentage points above it; measured number inside the range.
By their numbers in this assay, from the lowest: compounds 4, 3, 2 and 1 (each within the scatter of the next, the first and the last beyond it).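

In this assay the exchange of pyridin-2-yl for pyridin-3-yl on the amide-type nitrogen gives a number 5 percentage points lower from compound 3 to compound 4 (within the scatter), so these two pyridine attachments are not told apart at this position even though the same atoms are joined differently. Compound 4 does separate from both fluorophenyl compounds, with a number 15 percentage points lower from compound 2 to compound 4 (beyond the scatter) and a number 22 percentage points lower from compound 1 to compound 4 (beyond the scatter), whereas compound 3 stood clear only of compound 1, so the gap between pyridine and fluorophenyl groups here is not uniform. Nothing available accounts for these differences.

The compounds shown leave open how pyridin-4-yl, an unsubstituted phenyl or a saturated piperidine ring would behave on this nitrogen. They also leave open whether a methoxy group or an amine on the pyridine ring would shift the maximal response.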